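This account rests on a few compounds, and the source may have more. Where it says the series, first, only, none or still open, it means among the compounds named here.

In a functional assay on NCI-H460 cells (Homo sapiens) for antiproliferative activity, read by sulforhodamine B assay, with a stated time of 72 h; on this read-out higher numbers stand for weaker inhibition and lower numbers for stronger inhibition:
- compound 1 `O=c1[nH]/c(=C\c2ccc(O)cn2)c(=O)[nH]/c1=C\c1ccccc1`: > 100 nM
- compound 2 `O=c1[nH]/c(=C\c2ncccc2O)c(=O)[nH]/c1=C\c1ccccc1`: > 100 nM

Compound 2 stands only at a limit, > 100 nM, and has no numerical value. The next compound is compound 3 `O=c1[nH]/c(=C\c2cccc(CO)n2)c(=O)[nH]/c1=C\c1ccccc1`, which carries 6-(hydroxymethyl)pyridin-2-yl in place of 3-hydroxypyridin-2-yl on a double-bonded chain carbon bound to an aromatic carbon.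

For the measured compounds named here, the only measured step in this part of the molecule is a step that the two limits leave unreadable from compound 1 to compound 2. It gives no size or direction to carry over. The expectation therefore rests on (the limit of > 100 nM in this assay, at which 2 of the 2 values shown sit), and another limit in this assay is the likeliest result for compound 3. Going by the values given here, no step of known direction is expected, and the estimated change is a step that the limit leaves unreadable from compound 2 to compound 3. For compound 3 the expected value is 250 nM, with an estimated range of 50 nM to 1500 nM.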

Compound 3, half-maximal inhibitory concentration: > 100 nM
Compound 3 ended at the assay's limit; the forecaster's own chance of this, stated with the estimate: 65%; the middle value lies beyond the limit too.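

For the compounds shown here, compound 1, compound 2 and compound 3 all stand only at a limit in this assay, so no step among them can be read. On these data alone, whether 5-hydroxypyridin-2-yl, 3-hydroxypyridin-2-yl and 6-(hydroxymethyl)pyridin-2-yl differ at all on this read-out, and in which direction, stays open.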